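Moving a trifluoromethyl group on a benzyl ether

The compounds below may be only part of what the source reports. "The series", "measured", "known", "first", "only" and "open" are said of these compounds alone.

Measured compounds and their values:
Compound 1, `Cc1ccc(NC(=S)NC(=O)c2ccc(OCc3ccc(C(F)(F)F)cc3)cc2)cc1-c1nc2ccccc2[nH]1`, gives 17600 nM in a functional assay on HT-29 cells (Homo sapiens) for inhibition, read by MTT assay, with a stated time of 48 h; a lower number here means a stronger inhibitor, a higher number a weaker inhibitor.
Compound 2, `Cc1ccc(NC(=S)NC(=O)c2ccc(OCc3cccc(C(F)(F)F)c3)cc2)cc1-c1nc2ccccc2[nH]1`, gives 8200 nM in this assay.
Compound 3, `Cc1ccc(NC(=O)NC(=O)c2ccc(OCc3ccc(C(F)(F)F)cc3)cc2)cc1-c1nc2ccccc2[nH]1`, gives 7830 nM in this assay.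

Compound 4, `Cc1ccc(NC(=O)NC(=O)c2ccc(OCc3cccc(C(F)(F)F)c3)cc2)cc1-c1nc2ccccc2[nH]1`, has not yet been measured. It differs from compound 3 in one place: 3-(trifluoromethyl)phenyl in place of 4-(trifluoromethyl)phenyl on a saturated chain carbon bound to an oxygen on an aromatic ring. The same kind of change turns compound 1 into compound 2, where it reads 3-(trifluoromethyl)phenyl in place of 4-(trifluoromethyl)phenyl on a saturated chain carbon bound to an oxygen on an aromatic ring and gave a 2.1-fold lower number from compound 1 to compound 2 (0.33 log units; beyond the scatter). The two pairs sit on different cores; how the core of compound 3 differs from that of compound 1 is not broken down here. The values of compound 2 and compound 3 lie within the usual scatter of each other, so nothing can be said about their order.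

For the measured compounds named here, with only one earlier example of this change, a step of about the same size is expected, a 2.1-fold lower number from compound 3 to compound 4 (0.33 log units; beyond the scatter), resting on compound 1 to compound 2 with a 2.1-fold lower number from compound 1 to compound 2 (0.33 log units; beyond the scatter). Compound 4 is therefore estimated at 3700 nM in this assay, plausibly between 1500 nM and 9000 nM.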

Compound 4, half-maximal inhibitory concentration: 3520 nM
The estimate for compound 4 lay 1.1-fold (0.02 log units) above the measured number; measured number inside the range.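

In this assay, swapping 4-(trifluoromethyl)phenyl for 3-(trifluoromethyl)phenyl gives a 2.2-fold lower number from compound 3 to compound 4 (0.35 log units; beyond the scatter), so the change carries over from one core to the other with its direction and size intact: the same change on two cores in this assay, a 2.1-fold lower number (0.33 log units; beyond the scatter) from compound 1 to compound 2 and a 2.2-fold lower number (0.35 log units; beyond the scatter) from compound 3 to compound 4, 1.0-fold (0.02 log units) apart, within the scatter of two such steps

In both pairs the 3-(trifluoromethyl)benzyl ether gives the lower number, and neither pair goes against this, so the step measured on one of these two cores was a fair guide to the step on the other. For the compounds shown here, this rests on only two pairs in a single cell assay, however, so it does not show that the change would behave the same way on a third core, and it does not explain why the step occurs or why it stays the same size.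

The compounds shown leave open whether the same move would give a similar step with a chlorine atom or a methoxy group in place of trifluoromethyl. They also leave open what a longer chain in place of the saturated chain carbon would do.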